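The source may report more compounds than this note shows. Statements on the series, on what has been measured and on what is new or still open speak of the compounds shown alone.

Compound 1, `COc1ccc2cc(-c3ccccc3)c(O)nc2c1`: 10000 nM
Compound 2, `COc1ccc(-c2cc3c(OC)ccc(OC)c3nc2O)cc1`: 10000 nM
Compound 3, `COc1ccc(-c2cc3c(OC)cc(OC)cc3n(C)c2=O)cc1`: 10000 nM

All three were tested in a functional assay on A549 cells (Homo sapiens) for cytotoxicity, read by colorimetric assay and MTT assay; a higher number here means a weaker inhibitor, a lower number a stronger inhibitor. In this assay compound 3 gives 10000 nM, which is level with compound 1 at 10000 nM and level with compound 2 at 10000 nM; at the digits shown the three cannot be told apart, and any gaps between them fall within the usual scatter. Compound 3 thus stands in a group in which the differences among the shared core and its attached groups leave the read-out unmoved.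

Compound 4, `COc1ccc(-c2cc3c(OC)cc(OC)cc3n(CC#N)c2=O)cc1`, has not yet been measured. It differs from compound 3 in one place: cyano in place of hydrogen on a saturated chain carbon bound to an aromatic nitrogen. For the measured compounds named here, no pair of measured compounds differing in one place exists here, so nothing in these data shows how such a change moves the read-out in this assay. What the data do show is that three compounds with different substitution on the core all land on the same value. On that basis the step from compound 3 to compound 4 is expected to be no change at the digits printed from compound 3 to compound 4 (within the scatter), that is, no change beyond the scatter in this assay. Compound 4 is therefore estimated at 10000 nM, with a range from 3000 nM to 30000 nM.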

Compound 4, half-maximal inhibitory concentration: 10000 nM
Estimate against measurement, compound 4: no gap at the digits printed; low and high end bracket the measured number.
By their numbers in this assay, from the lowest: compounds 1, 2, 3 and 4 (each within the scatter of the next).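

For the compounds shown here, the first comparison in this assay that changes one place only reads no change at the digits printed from compound 3 to compound 4 (within the scatter), and it concerns cyano in place of hydrogen on a saturated chain carbon bound to an aromatic nitrogen, which is the same as going from methyl to cyanomethyl. The earlier compounds shown here differ from one another in more than one place, so they could say nothing about a single change; this pair shows that the read-out stays put when this one group is swapped at this one position. No measurement at hand accounts for this lack of movement.

The compounds shown leave open whether a different group on this chain, such as an amine, a carboxylic acid or a longer chain, would move the number in this assay. They also leave open whether any change at this position can shift the read-out away from the value that compound 3 gives, 10000 nM, or whether a change elsewhere on the shared core would be needed.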